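Alkynyl chain in place of chlorovinyl on the deoxyuridine core

This account rests on a few compounds, and the source may have more. Where it says the series, first, only, none or still open, it means among the compounds named here.

Measured so far in this cytotoxicity series:
compound 1 `C=C(Cl)c1cn([C@H]2C[C@H](O)[C@@H](CO)O2)c(=O)[nH]c1=O` — 1660 nM
compound 2 `C[C@@]1(CO)O[C@H](c2ccc(N)cc2F)C[C@@H]1O` — > 200000 nM
compound 3 `CC(=O)OC(C)Cn1cnc2c(N)nc(I)nc21` — > 200000 nM

In an ADME assay on L1210/0 cells (Mus musculus) for cytotoxicity, with a stated time of 48 h (a higher number here means a weaker inhibitor, a lower number a stronger inhibitor), compound 1 gives 1660 nM, the only numerical result among the three. Compound 2 reaches only a limit, > 200000 nM. Compound 3 likewise stops at a limit, > 200000 nM. What the set shows is the limit of > 200000 nM in this assay, at which 2 of the 3 values shown sit. For the measured compounds named here, no step between measured compounds can be drawn, so no measured change of a single group is available for comparison.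

Compound 4 `CCCCCC#Cc1cn([C@H]2C[C@H](O)[C@@H](CO)O2)c(=O)[nH]c1=O` differs from compound 1 by hept-1-yn-1-yl in place of 1-chloroethenyl on an aromatic carbon. Going by the values given here, with no measured step to lean on, the change is expected to cost potency by a margin beyond the scatter: a 12-fold higher number from compound 1 to compound 4 (1.08 log units; beyond the scatter). Compound 4 is therefore expected to give 20000 nM, in a range from 3000 nM to 150000 nM, with some chance that only a limit is reported.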

Compound 4, half-maximal inhibitory concentration: > 200000 nM
Compound 4: no number, only a limit; the forecaster's own chance of this, stated with the estimate: 25%; at least 10-fold (1.00 log units) between middle value and limit.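

For the compounds shown here, at this position, hept-1-yn-1-yl in place of 1-chloroethenyl gives an at least 120-fold higher number from compound 1 to compound 4 (2.08 log units; beyond the scatter) on the shared core, the first step that can be read. That step is a bound only, as the result for compound 4 is a limit and not a number. Compound 1 remains the only compound with a numerical result in this assay and the others end at the limit: the limit of > 200000 nM in this assay, at which 3 of the 4 values shown sit.

Open, on these data alone, is whether a shorter alkynyl chain such as ethynyl or prop-1-yn-1-yl on the same carbon returns a numerical result. A saturated heptyl chain would show whether the triple bond or the chain length goes with the step.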